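Pyridin-3-yl for phenyl on the hydrazone carbon

The source may report more compounds than this note shows. Statements on the series, on what has been measured and on what is new or still open speak of the compounds shown alone.

The series is followed in a functional assay on the whole organism (strain Wistar) for inhibition, with Rattus norvegicus as the target, read by paw edema, with a stated time of 4 h, at a dose of 10 mg/kg by the intraperitoneal route; on this read-out higher numbers stand for more inhibition at the one dose given (going by the name of the read-out) and lower numbers for less inhibition. Compound 1 `O=C(N/N=C/c1ccccc1)c1cccnc1Nc1cccc(C(F)(F)F)c1` gives 31% in this assay. Compound 2 `O=C(N/N=C/c1cccnc1)c1cccnc1Nc1cccc(C(F)(F)F)c1` differs from compound 1 by pyridin-3-yl in place of phenyl on a carbon with a double bond to nitrogen. In this assay compound 2 gives 36%, a step of a number 5 percentage points higher from compound 1 to compound 2 (within the scatter). Compound 3 `CNc1ncccc1C(=O)N/N=C/c1ccccc1` carries a different core; the difference between the two cores is not broken down here. In this assay compound 3 gives 14.8%, the lowest of the three numbers, and its gaps to compound 1 and compound 2 lie beyond the scatter.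

Compound 4 `CNc1ncccc1C(=O)N/N=C/c1cccnc1` is not yet measured. It stands to compound 3 as compound 2 stands to compound 1: pyridin-3-yl in place of phenyl on a carbon with a double bond to nitrogen. Both place lines read the same word for word, so this is the same change, made twice in all among the compounds shown.

For compound 4 a step of a number 5.2 percentage points higher from compound 3 to compound 4 (within the scatter) in this assay is expected, because a number 5 percentage points higher from compound 1 to compound 2 (within the scatter) was within the scatter, and the same size is assumed on the second core. Compound 4 is therefore estimated at 20% in this assay, with a range from 8% to 32%.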

Compound 4, a percentage reported as inhibition, in the whole organism at one dose (the size of the read-out at that dose, not a potency): 13.8%
Estimate against measurement, compound 4: 6.2 percentage points above; low and high end bracket the measured number.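

In this assay, going by these compounds alone, pyridin-3-yl in place of phenyl on a carbon with a double bond to nitrogen gives a number 1 percentage points lower from compound 3 to compound 4 (within the scatter), so on this core the change yields no step that stands clear of the scatter. Set beside the earlier step, the result gives no sign that the change behaves differently on the two cores: the same change on two cores in this assay, a number 5 percentage points higher (within the scatter) from compound 1 to compound 2 and a number 1 percentage points lower (within the scatter) from compound 3 to compound 4, 6 percentage points apart, within the scatter of two such steps
Within the data shown here, this shows only that neither core yields a step beyond the scatter at the one dose and time tested; it does not show that the two cores respond identically, and two cores support no rule for the wider series.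

From the compounds shown here alone, it remains open whether pyridin-4-yl or a phenyl bearing a carboxylic acid, placed on the same carbon, would give a step beyond the scatter. Also open, going by these compounds, is whether the near-absence of a step would hold on a third core carrying a longer chain or at other doses.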